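The source may report more compounds than this note shows. Statements on the series, on what has been measured and on what is new or still open speak of the compounds shown alone.

Three ureas built on one shared core have been measured in an assay on isolated protein for inhibition of STE20-like serine/threonine-protein kinase (Homo sapiens), read by thermal shift assay, tested at 10 uM; a higher number here means that the compound stabilises the target more against heat, a lower number that the compound stabilises the target less. Compound 1 `CCOc1ccc(NC(=O)Nc2cc(C(C)(C)C)nn2-c2ccccc2)cc1` carries a 4-ethoxyphenyl on an amide-type nitrogen and in this assay compound 1 gives 1.1 degrees C. Compound 2 `Cc1cc(C)cc(NC(=O)Nc2cc(C(C)(C)C)nn2-c2ccccc2)c1` gives 2.4 degrees C in this assay. Compound 3 `Cc1ccc(F)cc1NC(=O)Nc1cc(C(C)(C)C)nn1-c1ccccc1` gives 6 degrees C in this assay, the highest of the three numbers: its nearest neighbour is compound 2, with the step of a number 3.6 degrees C higher from compound 2 to compound 3 (beyond the scatter), and the furthest is compound 1, with the step of a number 4.9 degrees C higher from compound 1 to compound 3 (beyond the scatter). The remaining pair shows the step of a number 1.3 degrees C higher from compound 1 to compound 2 (beyond the scatter).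

Compound 4 `CC(C)(C)c1cc(NC(=O)Nc2ccccc2)n(-c2ccccc2)n1` is the next member. The change from compound 3 is phenyl in place of 5-fluoro-2-methylphenyl on an amide-type nitrogen. Among the compounds with values here, the steps that bear on this are the two that altered the same aryl group, namely a number 4.9 degrees C higher from compound 1 to compound 3 (beyond the scatter) and a number 3.6 degrees C higher from compound 2 to compound 3 (beyond the scatter), both beyond the scatter. Given those two steps, a number lower than that of compound 3 is expected for compound 4 in this assay. Compound 4 is therefore estimated at 2.5 degrees C, within 0.5 degrees C to 5 degrees C. The expected step is a number 3.5 degrees C lower from compound 3 to compound 4 (beyond the scatter).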

Compound 4, shift of the target's melting temperature: 7.7 degrees C
Compound 4: middle estimate off by 5.2 degrees C, on the low side, outside the stated range (above it).
By their numbers in this assay, from the lowest: compound 1; then compound 2; then compound 3; then compound 4.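

The plain phenyl on the amide-type nitrogen gives the highest number of the four in this assay, with a number 1.7 degrees C higher from compound 3 to compound 4 (beyond the scatter) and a number 5.3 degrees C higher from compound 2 to compound 4 (beyond the scatter) as well as a number 6.6 degrees C higher from compound 1 to compound 4 (beyond the scatter) at this one position. The earlier compounds shown here ranked only substituted aryl groups against one another, whereas compound 4 shows that the unsubstituted ring outranks all three of them, so the substituents on this ring are not needed for a high number. Nothing shown here accounts for this order.

The compounds shown leave open whether a lone fluorine or a lone methyl on this phenyl would keep the number of compound 4 or lower it. They also leave open what an amine or a carboxylic acid on the same ring would do.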